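The source may report more compounds than this note shows. Statements on the series, on what has been measured and on what is new or still open speak of the compounds shown alone.

Compound 2 `O=C(O)CC/C=C\CC1COC(c2ccco2)OC1c1cccnc1` is the starting point of this step. In an assay for inhibition of Thromboxane-A synthase (Homo sapiens), using microsomes (a higher number here means a weaker inhibitor, a lower number a stronger inhibitor), compound 2 gives 164 nM, the highest number of the three measured compounds and thus the weakest inhibitor among them. Compound 1 `N#Cc1ccc(C2OCC(C/C=C\CCC(=O)O)C(c3cccnc3)O2)cc1` gives 24 nM in this assay, and compound 3 `CC(C)(Oc1ccccc1)C1OCC(C/C=C\CCC(=O)O)C(c2cccnc2)O1` gives 52 nM. The change to compound 4 `CC(C)(Cc1ccccc1)C1OCC(C/C=C\CCC(=O)O)C(c2cccnc2)O1` is 1-benzyl-1-methylethyl in place of furan-2-yl on a saturated ring carbon. The closest comparison already measured is a 3.2-fold lower number from compound 2 to compound 3 (0.50 log units; beyond the scatter), where a group of 10 heavy atoms with one six-membered aromatic ring of carbon only also replaced the furan-2-yl on the same saturated ring carbon. The step of a 6.8-fold higher number from compound 1 to compound 2 (0.83 log units; beyond the scatter) likewise shows that the furan-2-yl gives the highest number of the three. Both steps are modest, so a modest fall in number is expected for compound 4, of about a 3.0-fold lower number from compound 2 to compound 4 (0.47 log units; beyond the scatter). Compound 4 is therefore estimated at 55 nM in this assay, expected to lie within 20 nM to 150 nM.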

Compound 4, half-maximal inhibitory concentration: 12 nM
For compound 4 the middle estimate is 4.6-fold (0.66 log units) above the measured one; measured number below the stated range.
By their numbers in this assay, from the lowest: compounds 4 and 1 (each within the scatter of the next); then compound 3; then compound 2.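

On this saturated ring carbon between two ring oxygen atoms, the 1-benzyl-1-methylethyl group gives a 14-fold lower number from compound 2 to compound 4 (1.14 log units; beyond the scatter) in this assay, the only large step among these compounds. Benzyl in place of phenoxy gives a 4.3-fold lower number from compound 3 to compound 4 (0.64 log units; beyond the scatter) on an otherwise identical group, so the link to the aromatic ring counts here, and not only the presence of that ring. The step of a 2.0-fold lower number from compound 1 to compound 4 (0.30 log units; within the scatter) means that the 1-benzyl-1-methylethyl and 4-cyanophenyl groups cannot be told apart in this measurement.

Nothing shown here accounts for these differences. On these data alone, whether a longer chain in place of the benzyl, or an amine on its aromatic ring, would keep the number as low remains open.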